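The source may hold more compounds than are shown below. What is called first, only, known or untested is meant among the compounds shown, and "the series" means these compounds.

Compound 1 `Cc1cccc(N(C)S(=O)(=O)C2CC3OC2C(c2ccc(NC(=O)CCCCCCC(=O)O)cc2)=C3c2ccc(O)cc2)c1`: > 100000 nM
Compound 2 `CCN(c1ccc(OC)cc1)S(=O)(=O)C1CC2OC1C(c1ccc(NC(=O)CCCCCCC(=O)O)cc1)=C2c1ccc(O)cc1`: 24400 nM

Compound 1 gives > 100000 nM in a functional assay on DU-145 cells (Homo sapiens) for antiproliferative activity, read by MTT assay, with a stated time of 72 h (on this read-out lower numbers stand for stronger inhibition and higher numbers for weaker inhibition), and this is a limit of the assay. Going by the values given here, compound 2 gives 24400 nM, so it holds the only actual number so far. Compound 3 `CCN(c1ccc(Cl)cc1)S(=O)(=O)C1CC2OC1C(c1ccc(NC(=O)CCCCCCC(=O)O)cc1)=C2c1ccc(O)cc1` has chloro in place of methoxy on an aromatic carbon, para to a large group (chloro in place of methoxy on an aromatic carbon). Among the compounds with values here, only one measured step bears on this change: an at least 4.0-fold lower number from compound 1 to compound 2 (0.61 log units; beyond the scatter). It altered the whole amino group on the sulfonyl sulfur, so it shows that this group can move the number but does not isolate methoxy. Within the data shown here, no measured step gives a direction for the swap, so the expected result is a small change in this assay, possibly none beyond the scatter: a 1.0-fold higher number from compound 2 to compound 3 (0.01 log units; within the scatter). For compound 3 the estimated value is 25000 nM, with an expected range of 9000 nM to 80000 nM.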

Compound 3, half-maximal inhibitory concentration: 42100 nM
Compound 3: middle estimate off by 1.7-fold (0.23 log units), on the low side; measured number inside the range.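

In this assay, chloro in place of methoxy, on an aromatic carbon para to a large group, gives a 1.7-fold higher number from compound 2 to compound 3 (0.24 log units; within the scatter), so this pair shows that the swap at this place does not separate the two groups beyond the usual scatter. The (4-chlorophenyl)(ethyl)amino group also differs from methyl(3-methylphenyl)amino on the sulfonyl sulfur, with an at least 2.3-fold lower number from compound 1 to compound 3 (0.37 log units; beyond the scatter), so the gap first seen with compound 2 does not require methoxy. That step gives only a bound and not a full size because compound 1 stands at a limit of the assay: the limit of > 100000 nM in this assay, at which 1 of the 3 values shown sits.

Going by these compounds, whether an amine or a nitrile at this place would move the number beyond the scatter stays open. Also open, on these data alone, is which part of the amino group carries the gap from compound 1, since the ethyl and the ring substituent change together in these steps.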